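Working notes: pyridin-4-yl in place of 2,6-difluorophenyl

The source may hold more compounds than are shown below. What is called first, only, known or untested is meant among the compounds shown, and "the series" means these compounds.

Within the data shown here, in a functional assay for inhibition, with Homo sapiens as the target (a higher number here means a weaker inhibitor, a lower number a stronger inhibitor), compound 1 `COc1cc(OC)c(C(=O)/C=C/c2ccc(Cl)cc2)c(OC)c1` gives 970 nM and compound 2 `COc1cc(OC)c(C(=O)/C=C/c2c(F)cccc2F)c(OC)c1` gives 1290 nM on the shared core, so compound 2 stands within the scatter of the only other measured compound. Compound 3 `COc1cc(OC)c(C(=O)/C=C/c2ccncc2)c(OC)c1` carries pyridin-4-yl in place of 2,6-difluorophenyl on a double-bonded chain carbon bound to a double-bonded chain carbon. Among the measured compounds shown here, one measured step bears on this place (a 1.3-fold higher number from compound 1 to compound 2 (0.12 log units; within the scatter)). It exchanges one phenyl group for another and stays within the scatter. For the measured compounds named here, no measured compound here has a hetero atom in this ring, so the evidence for the new group is thin. No step beyond the scatter is expected in this assay and the estimated step (a 1.4-fold higher number from compound 2 to compound 3 (0.14 log units; within the scatter)) carries a wide margin. For compound 3 the estimate is 1800 nM with a range from 600 nM to 5000 nM as the expected span.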

Compound 3, half-maximal inhibitory concentration: 592 nM
Beside the measured number, compound 3's estimate is 3.0-fold (0.48 log units) above it; measured number outside the range, below it.
By their numbers in this assay, from the lowest: compounds 3, 1 and 2 (each within the scatter of the next, the first and the last beyond it).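

In this assay, among these compounds, the measured change of pyridin-4-yl in place of 2,6-difluorophenyl gives a 2.2-fold lower number from compound 2 to compound 3 (0.34 log units; beyond the scatter) and is the first step at this place, on a double-bonded chain carbon bound to a double-bonded chain carbon, to pass the scatter, though only modestly. The same group in place of 4-chlorophenyl gives a 1.6-fold lower number from compound 1 to compound 3 (0.21 log units; within the scatter) and so does not separate these two rings, which shows that a six-membered aromatic ring with a hetero atom and a hydrogen-bond acceptor is accepted here without loss against either phenyl group. No supporting measurement accounts for these steps.

Whether the result depends on where the ring nitrogen sits remains open, as pyridin-3-yl and pyridin-2-yl do not appear among the compounds shown. Also open, going by these compounds, is how a ring carrying an amine or a carboxylic acid would behave at this place.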